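The compounds below may be only part of what the source reports. "The series", "measured", "known", "first", "only" and "open" are said of these compounds alone.

Measured so far in a functional assay on V79 cells (Cricetulus griseus) for cytotoxicity, read by colony formation; a lower number here means a stronger inhibitor, a higher number a weaker inhibitor:
- compound 1 `CNCC1(C)CCN(c2cc3c(cc2F)c(=O)c(C(=O)O)cn3C2CC2)C1`: 205 ug/mL
- compound 2 `CNCC1(C)CCN(c2c(F)cc3c(=O)c(C(=O)O)cn(C4CC4)c3c2OC)C1`: 120 ug/mL

With 120 ug/mL, compound 2 lies within the scatter of compound 1, so neither stands apart in this assay. Next is compound 3 `CNCC1(C)CCN(c2c(F)cc3c(=O)c(C(=O)O)cn(C4CC4)c3c2C(F)(F)F)C1`, which carries trifluoromethyl in place of methoxy on an aromatic carbon.

Within the data shown here, the only measured step that bears on this change is a 1.7-fold lower number from compound 1 to compound 2 (0.23 log units; within the scatter), for methoxy in place of hydrogen on an aromatic carbon. Among the measured compounds shown here, no measured compound carries trifluoromethyl, so this single small step is weak evidence, and the range has to stay wide. No shift beyond the scatter is expected in this assay, and no direction can be favoured with confidence.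

The expected change is a 1.2-fold higher number from compound 2 to compound 3 (0.07 log units; within the scatter). For compound 3 the estimated value is 140 ug/mL, with an expected range of 60 ug/mL to 320 ug/mL.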

Compound 3, half-maximal inhibitory concentration: 230 ug/mL
Beside the measured number, compound 3's estimate is 1.6-fold (0.22 log units) below it, within the range that was stated.
By their numbers in this assay, from the lowest: compounds 2, 1 and 3 (each within the scatter of the next).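

In this assay, trifluoromethyl on this aromatic carbon, ortho to the 3-methyl-3-((methylamino)methyl)pyrrolidin-1-yl group, gives a 1.9-fold higher number from compound 2 to compound 3 (0.28 log units; within the scatter) when it replaces methoxy. Among these compounds, replacing hydrogen with trifluoromethyl gives a 1.1-fold higher number from compound 1 to compound 3 (0.05 log units; within the scatter), so hydrogen, methoxy and trifluoromethyl at this place are not separated by this read-out, where the earlier compounds had offered only the hydrogen and methoxy pair. No measurement at hand accounts for this result.

On these data alone, whether an amine, a carboxylic acid or a longer alkyl chain on the same aromatic carbon would give a step beyond the scatter remains open. Also open is whether the same lack of separation among these three groups would hold outside this assay for this series.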